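Dimethylcarbamoyl to 5-methyl-1,3,4-oxadiazol-2-yl: working notes

The compounds below may be only part of what the source reports. "The series", "measured", "known", "first", "only" and "open" are said of these compounds alone.

- Compound 1 `COC(=O)c1nc(C)c2c(c1N)C(=O)N(Cc1ccccc1)C2=O` gives 7400 nM
- Compound 2 `Cc1nc(C(N)=O)c(N)c2c1C(=O)N(Cc1ccccc1)C2=O` gives < 5000 nM, a limit of the assay and not a number
- Compound 3 `Cc1nc(C(=O)N(C)C)c(N)c2c1C(=O)N(Cc1ccccc1)C2=O` gives 172000 nM

All values come from a physicochemical assay for solubility, using the shake flask method, in simulated intestinal fluid, measured as kinetic solubility, with a stated time of 2 h, at 25 degrees C, at pH 6.5; on this read-out lower numbers stand for lower solubility and higher numbers for higher solubility. Compound 3 holds the highest number of the three at 172000 nM, and compound 1 is its nearest neighbour with a number.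

Compound 4 `Cc1nnc(-c2nc(C)c3c(c2N)C(=O)N(Cc2ccccc2)C3=O)o1` is not yet measured. It carries 5-methyl-1,3,4-oxadiazol-2-yl in place of dimethylcarbamoyl on an aromatic carbon.

The measured steps that bear on this change all alter the group on the carbonyl carbon. Dimethylamino in place of methoxy gives a 23-fold higher number from compound 1 to compound 3 (1.37 log units; beyond the scatter), and dimethylamino in place of amino gives an at least 34-fold higher number from compound 2 to compound 3 (1.53 log units; beyond the scatter). Both are large. Amino in place of methoxy gives only an at least 1.4-fold lower number from compound 1 to compound 2 (0.17 log units; that floor lies within the scatter). Both large steps end at compound 3, and dimethylcarbamoyl leaves in compound 4, so a large step to a lower number is expected in this assay, back toward compound 1 at 7400 nM. Among the measured compounds shown here, no measured step replaces the carbonyl group with a ring, so the size of the step remains uncertain.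

The expected change is a 17-fold lower number from compound 3 to compound 4 (1.24 log units; beyond the scatter). For compound 4 the estimated value is 10000 nM, with an expected range of 4000 nM to 50000 nM.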

Compound 4, solubility: < 5000 nM
Compound 4: a limit, no number (the forecaster's own chance of this, stated with the estimate: 30%); at least 2.0-fold (0.30 log units) between middle value and limit.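

In this assay compound 4 gives < 5000 nM, a limit of the assay and not a number. Among the compounds shown here, on the aromatic carbon next to the ring nitrogen and ortho to the amino group, 5-methyl-1,3,4-oxadiazol-2-yl in place of dimethylcarbamoyl gives an at least 34-fold lower number from compound 3 to compound 4 (1.53 log units; beyond the scatter), so the high number of compound 3 does not carry over to this five-membered aromatic ring, a replacement that no earlier step covered. Against methoxycarbonyl, the same ring gives an at least 1.4-fold lower number from compound 1 to compound 4 (0.17 log units; that floor lies within the scatter), while the step between the two limits cannot be read, which leaves compound 4 unordered against compound 2 and puts a second group at the floor of the read-out: the limit of < 5000 nM in this assay, at which 2 of the 4 values shown sit.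

As far as these compounds go, how far compound 4 lies under the limit stays open, and with it any difference between the 5-methyl-1,3,4-oxadiazol-2-yl and carbamoyl groups at this position. Also open, from the compounds shown here alone, is whether the high number belongs to dimethylcarbamoyl alone or extends to other amides on the same carbon, such as a morpholine amide or a pyrrolidine amide, or to a carboxylic acid.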